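Sulfanyl chain variation and cytotoxicity on gastric cells

The compounds below may be only part of what the source reports. "The series", "measured", "known", "first", "only" and "open" are said of these compounds alone.

Going by the values given here, compound 2 `Cc1cc(N2CC[C@@H](C)[C@@H](N(C)c3ncnc4[nH]ccc34)C2)n2nc(SCC3CCCCC3)nc2n1` gives 98200 nM in a toxicity assay on GES1 cells (Homo sapiens) for inhibition, read by MTT assay, with a stated time of 72 h (a lower number here means a stronger inhibitor, a higher number a weaker inhibitor), the higher of the two numbers measured so far; compound 1 `CCCSc1nc2nc(C)cc(N3CC[C@@H](C)[C@@H](N(C)c4ncnc5[nH]ccc45)C3)n2n1` gives 67100 nM, and the two lie within the scatter of each other. Compound 3 `Cc1cc(N2CC[C@@H](C)[C@@H](N(C)c3ncnc4[nH]ccc34)C2)n2nc(SCCCc3ccccc3)nc2n1` is not yet measured. It differs from compound 2 at one place: phenethyl in place of cyclohexyl on a saturated chain carbon bound to a sulfur. Among the compounds with values here, the only measured step at this place is a 1.5-fold higher number from compound 1 to compound 2 (0.17 log units; within the scatter), which stayed within the scatter. The change to compound 3 again swaps one group on the saturated chain carbon bound to the sulfur, and the cyclohexyl that leaves is itself the group whose entry produced no shift beyond the scatter. Within the data shown here, with no measured step bearing on a phenethyl at this position, a step of a 1.1-fold lower number from compound 2 to compound 3 (0.04 log units; within the scatter) is expected, that is none beyond the scatter. Compound 3 is therefore estimated at 90000 nM, with a range of 40000 nM to 200000 nM.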

Compound 3, half-maximal inhibitory concentration: > 100000 nM
Compound 3 ended at the assay's limit; the forecaster's own chance of this, stated with the estimate: 30%; at least 1.1-fold (0.04 log units) between middle value and limit.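

Sulfanyl chain, working notes: in this assay compound 3 stands at a limit of the assay and not at a number: the limit of > 100000 nM in this assay, at which 1 of the 3 values shown sits. The exchange of cyclohexylmethyl for 3-phenylpropyl gives an at least 1.0-fold higher number from compound 2 to compound 3 (0.00 log units; that floor lies within the scatter), and adding phenyl to the chain of compound 1 gives an at least 1.4-fold higher number from compound 1 to compound 3 (0.17 log units; that floor lies within the scatter), so both steps are floors and neither is shown to go beyond the scatter. New at this position is that a six-membered aromatic ring on the chain, like the non-aromatic ring of compound 2, brings no lower number.

From the compounds shown here alone, how far compound 3 lies past the limit stays open, and with it whether either step really exceeds the scatter. Also open, going by these compounds, is whether an amine or a carboxylic acid on this sulfanyl chain would bring the number down.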